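A few compounds are considered here, and "the series" means these few. Any claim that something is new, unique, unknown or untested is made for them only; others in the source may bear on it.

In an ADME assay on THP-1 cells (Homo sapiens) for cytotoxicity, read by MTT assay, tested at 50 ug/mL (on this read-out lower numbers stand for less inhibition and higher numbers for more inhibition at the one concentration tested (going by the name of the read-out)), compound 1 `Fc1ccc(-c2csc(N/N=C/c3ccc(-n4cncn4)cc3)n2)cc1` gives 35.9%. Compound 2 `Clc1ccc(-c2csc(N/N=C/c3ccc(-n4cncn4)cc3)n2)c(Cl)c1`, which carries a 2,4-dichlorophenyl in place of the 4-fluorophenyl, gives 8.9% in this assay. Within the data shown here, that single swap is the only measured step here, a number 27 percentage points lower from compound 1 to compound 2 (beyond the scatter). Compound 2 therefore stands at the lower of the two numbers, with compound 1 as its nearest neighbour, a number beyond the usual scatter above it.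

The step to compound 3 `COc1ccc(-c2csc(N/N=C/c3ccc(-n4cncn4)cc3)n2)cc1` alters the same aromatic carbon: 4-methoxyphenyl in place of 2,4-dichlorophenyl on an aromatic carbon. Among the measured compounds shown here, the one measured step bears on it only loosely, because a number 27 percentage points lower from compound 1 to compound 2 (beyond the scatter) shows that exchanging one aryl group for another here can shift the read-out by a modest amount, yet no measured pair contains a methoxy-bearing ring, so the direction for compound 3 rests on thin ground. Compound 3, like compound 1, has a single substituent on its phenyl ring rather than the two chlorines of compound 2, so a number nearer to compound 1 is expected, a step of a number 16.1 percentage points higher from compound 2 to compound 3 (beyond the scatter). Compound 3 is estimated to give 25% in this assay, within a range from 5% to 50%.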

Compound 3, a percentage reported as inhibition, at one concentration (the size of the read-out at that concentration, not a potency): 23%
For compound 3 the middle estimate is 2 percentage points above the measured one; the measured number falls inside the stated range.
By their numbers in this assay, from the lowest: compound 2; then compound 3; then compound 1.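

In this assay the third aryl group shows that this position does not simply divide the two-chlorine ring from the single-substituent rings, since the measured step of a number 14.1 percentage points higher from compound 2 to compound 3 (beyond the scatter) is joined by a second one, a number 12.9 percentage points lower from compound 1 to compound 3 (beyond the scatter) and both lie beyond the usual scatter. The second step is the more informative, as it keeps one substituent on the phenyl ring and exchanges only fluoro for methoxy, so the read-out responds to the identity of that single group and not just to the presence of the two chlorines of the 2,4-dichlorophenyl. The three compounds now form a graded series with compound 3 in the middle, but nothing supplied here accounts for that order.

The compounds shown do not separate the contribution of the two chlorines, so a phenyl ring carrying a single chlorine could fall nearer to either compound 2 or compound 1. Where a plain unsubstituted phenyl, or a phenyl ring bearing an amine or a carboxylic acid, would fall in this series also remains open.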